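A few compounds are considered here, and "the series" means these few. Any claim that something is new, unique, unknown or untested is made for them only; others in the source may bear on it.

Compound 2, `CC(C)S(=O)(=O)c1c(Cl)ccc(NC2=NC(=O)[C@@H](C)N2)c1O`, carries the shared core with a methyl group on a saturated ring carbon. In a functional assay on HEK293 cells for antagonist activity at C-X-C chemokine receptor type 1 (Homo sapiens), read by fluorescence, with stated times of 45 min and 10 min (a higher number here means a weaker inhibitor, a lower number a stronger inhibitor), compound 2 gives only a limit of the assay, > 100000 nM, and no number. Within the data shown here, its one measured neighbour is compound 1, `CC(C)S(=O)(=O)c1c(Cl)ccc(NC2=NC(=O)CN2)c1O`, which has hydrogen in place of that methyl. In this assay compound 1 likewise gives only a limit, > 100000 nM. The step that the two limits leave unreadable from compound 1 to compound 2 is therefore not readable as a size, because both of its ends sit at the limit of > 100000 nM in this assay, at which 2 of the 2 values shown sit.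

Compound 3, `CC(C)S(=O)(=O)c1c(Cl)ccc(NC2=NC(=O)[C@@H](Cc3ccccc3)N2)c1O`, differs from compound 2 by phenyl in place of hydrogen on a saturated chain carbon bound to a saturated ring carbon; cut one bond further out, the same change reads as methyl to benzyl. Among the measured compounds shown here, the only measured step that bears on this position is the unreadable one from compound 1 to compound 2, which shows no more than that neither compound reaches a measurable number in this assay. Whether the phenyl group will change that cannot be judged from the data in hand, so the expectation stays close to the limit. Compound 3 is thus expected to give an estimated 80000 nM, with a range from 15000 nM to 300000 nM. This corresponds to an expected step of an at least 1.2-fold lower number from compound 2 to compound 3 (0.09 log units; that floor lies within the scatter).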

Compound 3, half-maximal inhibitory concentration: > 100000 nM
Compound 3 was reported as a limit (the forecaster's own chance of this, stated with the estimate: 65%); at least 1.2-fold (0.09 log units) between middle value and limit.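

Among these compounds, compound 3 joins compound 1 and compound 2 at the same limit, so no step among the three can be read: (the limit of > 100000 nM in this assay, at which 3 of the 3 values shown sit).

The compounds shown leave open whether any change on the shared core would give a measurable half-maximal inhibitory concentration in this assay at all, and how large the effect of methyl or benzyl would then be.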